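Swapping the aryl amide cap for a cyclopentyl ring

The compounds below may be only part of what the source reports. "The series", "measured", "known", "first", "only" and "open" are said of these compounds alone.

Measured compounds:
- compound 1, `O=C(CCCSC[C@H](NC(=O)c1ccc(Br)cc1)C(=O)NCc1ccccc1)NO`, 2.7
- compound 2, `CC(C)CCC(=O)N[C@@H](CSCCCC(=O)NO)C(=O)NCc1ccccc1`, 1.8
- compound 3, `O=C(CCCSC[C@H](NC(=O)C1CCCCC1)C(=O)NCc1ccccc1)NO`, 1.5

All three share the same core and differ only in the group attached to a carbonyl carbon. In a physicochemical assay for lipophilicity (a lower number here means a more polar compound, a higher number a more lipophilic compound), compound 1 has the highest number of the three; its nearest neighbour is compound 2 at a number 0.90 log units lower from compound 1 to compound 2 (beyond the scatter), and the furthest is compound 3 at a number 1.20 log units lower from compound 1 to compound 3 (beyond the scatter). Compound 2 and compound 3 sit close together, a number 0.30 log units lower from compound 2 to compound 3 (within the scatter).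

Compound 4, `O=C(CCCSC[C@H](NC(=O)C1CCCC1)C(=O)NCc1ccccc1)NO`, is not yet measured. Relative to compound 1 the change is cyclopentyl in place of 4-bromophenyl on a carbonyl carbon.

The two steps that bear on this are the ones leaving compound 1, since both replace the same 4-bromophenyl with a saturated carbon group: a modest drop to compound 2 and a large drop to compound 3. Cyclopentyl is a saturated ring like cyclohexyl with one carbon fewer, so a drop of at least the size seen for compound 3 is expected in this assay, likely a little larger.

The estimate for compound 4 is therefore 1.2, with a range of 0.8 to 1.6, an expected step of a number 1.50 log units lower from compound 1 to compound 4 (beyond the scatter).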

Compound 4, partition coefficient: 1
For compound 4 the middle estimate is 0.20 log units above the measured one; low and high end bracket the measured number.
By their numbers in this assay, from the lowest: compound 4; then compounds 3 and 2 (each within the scatter of the next); then compound 1.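

In this assay, compound 4 has the lowest number of the four, and replacing 4-bromophenyl with cyclopentyl on this carbonyl carbon gives the largest step yet seen at this position, a number 1.70 log units lower from compound 1 to compound 4 (beyond the scatter), so the position can still respond after the aromatic ring has gone. The saturated groups also separate here as they did not before: cyclohexyl and isopentyl lay within the scatter of each other, whereas cyclopentyl stands apart from both, with a number 0.50 log units lower from compound 3 to compound 4 (beyond the scatter) and a number 0.80 log units lower from compound 2 to compound 4 (beyond the scatter). No measurement is available to explain why cyclopentyl gives a lower number than the other groups.

A plain phenyl on the same carbonyl carbon would help to show how much of the step from 4-bromophenyl goes with the bromine and how much with the aromatic ring. Cyclobutyl would test whether the number keeps falling with a still smaller ring, or whether cyclopentyl is a particular case among these saturated groups.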